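The source may report more compounds than this note shows. Statements on the series, on what has been measured and on what is new or still open speak of the compounds shown alone.

Measured compounds:
- compound 1 `CC#CCn1c(N2CCC[C@@H](N)C2)nc2c1c(=O)n(Cc1c(Br)cccc1C(=O)O)c(=O)n2C` — in an ADME assay on isolated protein for inhibition of Dipeptidyl peptidase 9 (Homo sapiens), with stated times of 15 min, 60 s and 20 min (a lower number here means a stronger inhibitor, a higher number a weaker inhibitor), compound 1 gives only a limit, > 100000 nM.
- compound 2 `CC#CCn1c(N2CCC[C@@H](N)C2)nc2c1c(=O)n(Cc1c(Cl)cccc1C(=O)OC)c(=O)n2C` — in this assay compound 2 gives only a limit, > 100000 nM.
- compound 3 `CC#CCn1c(N2CCC[C@@H](N)C2)nc2c1c(=O)n(Cc1cc(Br)ccc1C(=O)O)c(=O)n2C` — in this assay compound 3 gives only a limit, > 100000 nM.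

Compound 2 thus stands nowhere on a scale of numbers: its result is a limit, and the two other values shown are limits as well. The steps between these compounds cannot be sized, a step that the two limits leave unreadable from compound 1 to compound 2, a step that the two limits leave unreadable from compound 2 to compound 3 and a step that the two limits leave unreadable from compound 1 to compound 3, due to the limit of > 100000 nM in this assay, at which 3 of the 3 values shown sit.

Compound 4 `CC#CCn1c(N2CCC[C@@H](N)C2)nc2c1c(=O)n(Cc1ccc(Br)cc1C(=O)O)c(=O)n2C` is not yet measured. It differs from compound 2 by 4-bromo-2-carboxyphenyl in place of 2-chloro-6-(methoxycarbonyl)phenyl on a saturated chain carbon bound to an aromatic nitrogen. Going by the values given here, every measured step that bears on this change is unreadable, so no step of a known size can be carried over, and no direction can be set for the change in this assay. The expectation for compound 4 is therefore that it also returns a limit, which means an expected step of a number no higher from compound 2 to compound 4 (the limit leaves the size open). Compound 4 is expected at 100000 nM, estimated within 30000 nM to 300000 nM.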

Compound 4, half-maximal inhibitory concentration: > 100000 nM
Compound 4 was reported as a limit (the forecaster's own chance of this, stated with the estimate: 80%); the middle value lies on the limit itself.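

The steps from compound 1, compound 2 and compound 3 to compound 4 cannot be read, due to the shared limit: the limit of > 100000 nM in this assay, at which 4 of the 4 values shown sit. The compounds shown leave open how strongly each one inhibits in this assay, and whether swapping these substituted phenyl groups changes the result at all.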